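Valine-to-isoleucine swap in a macrocyclic depsipeptide series

A few compounds are considered here, and "the series" means these few. Any claim that something is new, unique, unknown or untested is made for them only; others in the source may bear on it.

compound 1 `CO[C@@H]1C[C@@H]2O[C@@]2(C)C(=O)N(C)[C@@H](C(C)C)C(=O)N[C@H](Cc2cc(Cl)c(O)c(Cl)c2)C(=O)N[C@@H](C(C)(C)O)C(=O)O[C@H](c2ccccc2)[C@H](C)/C=C/C=C/1C` — 6.7 nM
compound 2 `CO[C@@H]1C/C=C(\C)C(=O)N(C)[C@@H](C(C)C)C(=O)N[C@H](Cc2ccccc2)C(=O)N[C@@H](C(C)C)C(=O)O[C@H](c2ccccc2)C/C=C/C=C/1C` — > 100 nM

Among the measured compounds shown here, in a functional assay on HCT-116 cells (Homo sapiens) for antiproliferative activity, read by MTT assay, with a stated time of 72 h (on this read-out higher numbers stand for weaker inhibition and lower numbers for stronger inhibition), compound 1 gives 6.7 nM, the only numeric reading in the set. For compound 2 the assay returns only a limit, (the limit of > 100 nM in this assay, at which 1 of the 2 values shown sits). Compound 3 `CC[C@H](C)[C@H]1C(=O)N[C@H](Cc2cc(Cl)c(O)c(Cl)c2)C(=O)N[C@@H](C(C)(C)O)C(=O)O[C@H](c2ccccc2)[C@H](C)/C=C/C=C(\C)[C@H](OC)C[C@@H]2O[C@@]2(C)C(=O)N1C` is not yet measured; it differs from compound 1 by methyl in place of hydrogen on a saturated chain carbon, two bonds along the chain from a saturated ring carbon, which read one bond further out is isopropyl to sec-butyl. For the measured compounds named here, no step between two measured compounds is available to gauge such a change. The expected step of a 1.2-fold higher number from compound 1 to compound 3 (0.08 log units; within the scatter) is none beyond the scatter, in either direction. Compound 3 is expected to give 8 nM (3 nM to 25 nM) in this assay.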

Compound 3, half-maximal inhibitory concentration: 17 nM
Beside the measured number, compound 3's estimate is 2.1-fold (0.33 log units) below it; the range from low to high includes it.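

Adding a methyl at this position is not silent: in this assay, the isopropyl to sec-butyl change gives a 2.5-fold higher number from compound 1 to compound 3 (0.40 log units; beyond the scatter). The step is modest, and compound 3 still returns a numeric reading of 17 nM, so the position accepts the sec-butyl group at some cost. Nothing measured here accounts for the step.

Open, as far as these compounds go, is whether a smaller ethyl group or a longer chain such as n-pentyl would extend this trend. Also open, from the compounds shown here alone, is how an amine or a carboxylic acid at this position would read.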